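From fluoro to trifluoromethyl: compound 3 to compound 4

A few compounds are considered here, and "the series" means these few. Any claim that something is new, unique, unknown or untested is made for them only; others in the source may bear on it.

In an ADME assay on cells (Hepatocyte, Mus musculus) for cytotoxicity, read by MTT assay, with a stated time of 24 h (on this read-out higher numbers stand for lower toxicity in this test and lower numbers for higher toxicity in this test), compound 3 `Cc1ccc(-c2nn(-c3ccccc3)cc2-c2nc3ccccc3n2S(=O)(=O)c2ccc(F)cc2)cc1` gives 167000 nM and compound 2 `Cc1ccc(-c2nn(-c3ccccc3)cc2-c2nc3ccccc3n2S(=O)(=O)c2cc(C)ccc2C)cc1` gives 231000 nM, two values within the scatter of each other. Compound 1 `Cc1ccc(-c2nn(-c3ccccc3)cc2-c2nc3ccccc3[nH]2)cc1`, with hydrogen in place of their sulfonyl group, gives > 300000 nM, which is a limit of the assay. Steps from it are therefore only floors: an at least 1.2-fold lower number from compound 1 to compound 2 (0.11 log units; that floor lies within the scatter) and an at least 1.7-fold lower number from compound 1 to compound 3 (0.25 log units; that floor lies within the scatter). Compound 4 `Cc1ccc(-c2nn(-c3ccccc3)cc2-c2nc3ccccc3n2S(=O)(=O)c2ccc(C(F)(F)F)cc2)cc1` carries trifluoromethyl in place of fluoro on an aromatic carbon. The nearest measured exchange at this group is a 1.4-fold lower number from compound 2 to compound 3 (0.14 log units; within the scatter). No step beyond the scatter is therefore expected, and the estimated step is a 1.0-fold lower number from compound 3 to compound 4 (0.02 log units; within the scatter). For compound 4 the expected value is 160000 nM, with an estimated range of 80000 nM to 300000 nM.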

Compound 4, half-maximal cytotoxic concentration: 89300 nM
Beside the measured number, compound 4's estimate is 1.8-fold (0.25 log units) above it; the measured number falls inside the stated range.
By their numbers in this assay, from the lowest: compounds 4, 3 and 2 (each within the scatter of the next, the first and the last beyond it). At a limit, above all of these: compound 1.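

In this assay the exchange of fluoro for trifluoromethyl on this aromatic carbon, para to a large group, gives a 1.9-fold lower number from compound 3 to compound 4 (0.27 log units; within the scatter) and so cannot be told from no change. The wider exchange on the sulfonyl sulfur gives a 2.6-fold lower number from compound 2 to compound 4 (0.41 log units; beyond the scatter) and is the first exchange of that group shown to pass the scatter, though only modestly.

Compound 1 remains a limit, so the size of any step from it stays unread: the limit of > 300000 nM in this assay, at which 1 of the 4 values shown sits. As far as these compounds go, whether an amine or a carboxylic acid on that aromatic carbon would move the number remains open.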